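The source may report more compounds than this note shows. Statements on the series, on what has been measured and on what is new or still open speak of the compounds shown alone.

Measured in a functional assay on M21 cells (Homo sapiens) for antiproliferative activity, read by sulforhodamine B assay, with a stated time of 48 h; a higher number here means a weaker inhibitor, a lower number a stronger inhibitor:
- compound 1 `Cc1ccccc1OS(=O)(=O)c1ccc(N2CCN(C)C2=O)cc1`: 2900 nM
- compound 2 `CCc1ccccc1OS(=O)(=O)c1ccc(N2CCN(C)C2=O)cc1`: 2300 nM
- compound 3 `CCCN1CCN(c2ccc(S(=O)(=O)Oc3ccccc3C)cc2)C1=O`: > 100000 nM (a limit, not a number)

In this assay compound 3 is reported only as > 100000 nM, which is a limit of the assay. The swap of methyl for propyl on the ring nitrogen, an ethyl in place of hydrogen on a saturated chain carbon bound to an amide-type nitrogen in a ring, gave an at least 34-fold higher number from compound 1 to compound 3 (1.53 log units; beyond the scatter).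

Compound 4 `CCCN1CCN(c2ccc(S(=O)(=O)Oc3ccccc3CC)cc2)C1=O` differs from compound 3 in one place: methyl in place of hydrogen on a saturated chain carbon bound to an aromatic carbon, which turns 2-methylphenyl into 2-ethylphenyl. The same change has been measured once, and it gave a 1.3-fold lower number from compound 1 to compound 2 (0.10 log units; within the scatter). That single pair carries the other group on the ring nitrogen, so it is only a guide. It gives no reason to expect a step beyond the scatter in this assay, in either direction.

The expected change is a number no higher from compound 3 to compound 4 (the limit leaves the size open). Compound 4 is estimated at 100000 nM, with an expected range from 20000 nM to 200000 nM, and it may well be reported only as a limit.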

Compound 4, half-maximal inhibitory concentration: > 50000 nM
Compound 4: no number, only a limit; the forecaster's own chance of this, stated with the estimate: 70%; the middle value is on the limit's open side.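

In this assay compound 4 is reported only as > 50000 nM, which is a limit of the assay. With 2-ethylphenyl in place of 2-methylphenyl, ethyl in place of hydrogen on a saturated chain carbon bound to an amide-type nitrogen in a ring again brings a large loss, an at least 21-fold higher number from compound 2 to compound 4 (1.33 log units; beyond the scatter), so the loss is no longer confined to a single pair. The step from compound 3 to compound 4 cannot be read, as both values are limits, and the methyl to ethyl change therefore remains readable only in the pair that carries methyl on the ring nitrogen.

The compounds shown leave open how an ethyl group or a chain ending in an amine on that ring nitrogen would read in this assay. They also leave open how a longer chain such as propyl would read in place of ethyl on the phenyl ring.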